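The source may report more compounds than this note shows. Statements on the series, on what has been measured and on what is new or still open speak of the compounds shown alone.

Working notes on the series. Compound 1 `O=c1cc(Cn2cc(C3CC3)nn2)c2ccc(O)cc2o1` is read only as a limit in a functional assay on SW-620 cells (Homo sapiens) for inhibition, read by MTT assay, with a stated time of 72 h (on this read-out higher numbers stand for weaker inhibition and lower numbers for stronger inhibition), where compound 1 gives > 100000 nM. Compound 2 `CCCCCCc1cn(Cc2cc(=O)oc3cc(O)ccc23)nn1` likewise reaches only a limit, giving > 100000 nM. Compound 3 `CCCCCCCCc1cn(Cc2cc(=O)oc3cc(O)ccc23)nn1` gives 50900 nM. Two of the three values sit at the limit of > 100000 nM in this assay, at which 2 of the 3 values shown sit. The step from compound 1 is an at least 1.9-fold lower number from compound 1 to compound 3 (0.29 log units; that floor lies within the scatter), the step from compound 2 is an at least 1.9-fold lower number from compound 2 to compound 3 (0.29 log units; that floor lies within the scatter), and a step that the two limits leave unreadable from compound 1 to compound 2. Compound 4 `O=c1cc(Cn2cc(-c3cc(F)cc(F)c3)nn2)c2ccc(O)cc2o1` differs from compound 1 by 3,5-difluorophenyl in place of cyclopropyl on an aromatic carbon. The measured steps all concern alkyl chains and none exchanges cyclopropyl for an aromatic ring, so they give no direct guide; a step of about an at least 1.6-fold lower number from compound 1 to compound 4 (0.22 log units; that floor lies within the scatter) is expected, within the scatter of compound 3. Compound 4 is therefore estimated at 60000 nM, between 15000 nM and 200000 nM, with a fair chance of only a limit again.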

Compound 4, half-maximal inhibitory concentration: 66700 nM
The estimate for compound 4 lay 1.1-fold (0.05 log units) below the measured number, and the stated range covers the measured number.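

In this assay, 3,5-difluorophenyl on this aromatic carbon gives a readable value, as octyl does, and the two cannot be told apart, with a 1.3-fold higher number from compound 3 to compound 4 (0.12 log units; within the scatter). Against cyclopropyl there is an at least 1.4-fold lower number from compound 1 to compound 4 (0.17 log units; that floor lies within the scatter), and against hexyl there is an at least 1.4-fold lower number from compound 2 to compound 4 (0.17 log units; that floor lies within the scatter), so neither floor establishes a real gain. Compound 1 and compound 2 are read only as limits: the limit of > 100000 nM in this assay, at which 2 of the 4 values shown sit.

Still open, from the compounds shown here alone, is whether any group on this carbon gives a step beyond the scatter. Going by these compounds, how an amine, a carboxylic acid or a chain longer than octyl would read there also remains open.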